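Adding a Third Methoxy to the Aryl Group

The source may report more compounds than this note shows. Statements on the series, on what has been measured and on what is new or still open speak of the compounds shown alone.

Among the measured compounds shown here, compound 2 `COc1ccc(C2CC(c3cc(Cl)c(C)cc3O)=NN2c2ccc(S(N)(=O)=O)cc2)cc1OC` gives 13700 nM in a functional assay on PC-3 cells (Homo sapiens) for antiproliferative activity, with a stated time of 48 h (on this read-out lower numbers stand for stronger inhibition of growth and higher numbers for weaker inhibition of growth), the highest of the two numbers so far, though its gap to compound 1 lies within the scatter. Compound 1 `Cc1cc(O)c(C2=NN(c3ccc(S(N)(=O)=O)cc3)C(/C=C/c3ccccc3)C2)cc1Cl` gives 11500 nM; the step is a 1.2-fold higher number from compound 1 to compound 2 (0.08 log units; within the scatter). Compound 3 `COc1ccc(C2CC(c3cc(Cl)c(C)cc3O)=NN2c2ccc(S(N)(=O)=O)cc2)c(OC)c1OC` differs from compound 2 by methoxy in place of hydrogen on an aromatic carbon. No measured step adds a methoxy group; the single step shown swaps the whole group and stays within the scatter, so nothing points to a large move. The step from compound 2 to compound 3 is expected to be a 1.1-fold lower number from compound 2 to compound 3 (0.02 log units; within the scatter), with no direction favoured. Compound 3 is estimated at 13000 nM, within 5000 nM to 35000 nM.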

Compound 3, concentration for total growth inhibition: 8940 nM
The estimate for compound 3 lay 1.5-fold (0.16 log units) above the measured number, within the range that was stated.
By their numbers in this assay, from the lowest: compounds 3, 1 and 2 (each within the scatter of the next).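

In this assay, a methoxy group on this aromatic carbon, ortho to a large group and ortho to a methoxy group, leaves the read-out essentially unmoved: the change gives a 1.5-fold lower number from compound 2 to compound 3 (0.19 log units; within the scatter). Putting 2,3,4-trimethoxyphenyl in place of 2-phenylethenyl on the saturated ring carbon likewise gives a 1.3-fold lower number from compound 1 to compound 3 (0.11 log units; within the scatter), so compounds 1, 2 and 3 cannot be told apart here. Nothing measured here bears on the reason for these small steps. As far as these compounds go, whether an amine or a carboxylic acid on this aromatic carbon would move the number beyond the scatter remains open.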